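The compounds below may be only part of what the source reports. "The series", "measured", "known", "first", "only" and "open" are said of these compounds alone.

Series notes. Of the compounds shown here, three have been measured in a physicochemical assay for lipophilicity; a higher number here means a more lipophilic compound, a lower number a more polar compound; a fourth has not. Compound 3 `O=C1/C(=C/c2ccccc2)CCC/C1=C\c1ccccc1[N+](=O)[O-]` gives 4.86 in this assay. Compound 1 `COc1ccc(/C=C2\CCC/C(=C\c3ccccc3[N+](=O)[O-])C2=O)cc1` carries the same core with one further group, and in this assay compound 1 gives 4.86. The change from compound 3 to compound 1 is methoxy in place of hydrogen on an aromatic carbon. The step it made in the partition coefficient is no change at the digits printed from compound 3 to compound 1 (within the scatter). Compound 2 `O=C1/C(=C/c2ccccc2)CCC/C1=C\c1ccc([N+](=O)[O-])cc1` holds the same atoms as compound 3, joined differently; the difference between the two cores is not broken down here. In this assay compound 2 gives 5.08, and its gaps to compound 1 and to compound 3 both lie within the usual scatter, so no order among the three is read from these numbers.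

Compound 4 `COc1ccc(/C=C2\CCC/C(=C\c3ccc([N+](=O)[O-])cc3)C2=O)cc1` is not yet measured. Compound 4 differs from compound 2 by methoxy in place of hydrogen on an aromatic carbon. This is the same change as from compound 3 to compound 1, with the place described in the same words, and among the four compounds it occurs twice in all. Within the data shown here, the only measured instance of it left the partition coefficient unchanged within scatter. On that footing the step from compound 2 to compound 4 is expected to be a number 0.02 log units higher from compound 2 to compound 4 (within the scatter). Among the measured compounds shown here, the expectation rests on the single earlier step of no change at the digits printed from compound 3 to compound 1 (within the scatter). Compound 4 is estimated at 5.1 in this assay, with a range from 4.8 to 5.4. With one precedent only, the range is kept wider than that step alone would suggest.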

Compound 4, partition coefficient: 5.08
Compound 4: the middle estimate sits 0.02 log units above what was measured, and the stated range covers the measured number.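

In this assay, among these compounds, the change of methoxy in place of hydrogen on an aromatic carbon (phenyl to 4-methoxyphenyl) now gives no change at the digits printed from compound 2 to compound 4 (within the scatter) on the core of compound 2, and it gave no change at the digits printed from compound 3 to compound 1 (within the scatter) on the core of compound 3, so both instances of the change agree in showing no step that stands clear of the scatter. This shows that the change carried across these two cores without a readable difference, but two pairs set no rule for other cores of the series, and a small step hidden inside the scatter on either core cannot be excluded. Nothing at hand explains this result.

Methoxy is the only group shown in place of that hydrogen, so it stays open how a dimethylamino group, a carboxylic acid, a chlorine atom or a longer alkoxy chain would read at the same place. Also open is how the methoxy change would read on a core without the nitro group, as both cores shown carry one.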